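Taking trifluoromethyl off compound 3

This account rests on a few compounds, and the source may have more. Where it says the series, first, only, none or still open, it means among the compounds named here.

Among the measured compounds shown here, in a functional assay on A549 cells (Homo sapiens) for antiproliferative activity, read by MTT assay, with a stated time of 48 h (on this read-out higher numbers stand for weaker inhibition and lower numbers for stronger inhibition), compound 3 (`O=C(/C=C/c1ccc(C(F)(F)F)cc1)Nc1nnc(-c2ccc(Cl)cc2)s1`) reads 3.09 ug/mL and has the highest number of the three compounds measured so far, which makes it the weakest inhibitor among them. Compound 1 (`Cc1ccc(/C=C/C(=O)Nc2nnc(-c3ccc(Cl)cc3)s2)cc1`) gives 1.25 ug/mL there and compound 2 (`Cc1ccc(-c2nnc(NC(=O)/C=C/c3ccccc3)s2)cc1`) gives 1.38 ug/mL there, two values that sit close together.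

The next compound is compound 4 (`O=C(/C=C/c1ccccc1)Nc1nnc(-c2ccc(Cl)cc2)s1`). It carries hydrogen in place of trifluoromethyl on an aromatic carbon, para to a large group (hydrogen in place of trifluoromethyl on an aromatic carbon).

The closest evidence is the swap of methyl for trifluoromethyl on an aromatic carbon, which gave a 2.5-fold higher number from compound 1 to compound 3 (0.39 log units; beyond the scatter) in this assay and counts as a modest step. For the measured compounds named here, no measured pair compares hydrogen with trifluoromethyl directly, so this is only indirect support. Though it differs elsewhere, compound 2 also carries hydrogen at that place and reads 1.38 ug/mL on the same test.

Removing trifluoromethyl is therefore expected to lower the number, and the expected change is a 1.8-fold lower number from compound 3 to compound 4 (0.26 log units; within the scatter) toward stronger inhibition. For compound 4 the estimate is 1.7 ug/mL with an expected range of 0.85 ug/mL to 3.4 ug/mL on this read-out.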

Compound 4, half-maximal inhibitory concentration: 2.02 ug/mL
For compound 4 the middle estimate is 1.2-fold (0.07 log units) below the measured one, and the stated range covers the measured number.
By their numbers in this assay, from the lowest: compounds 1, 2, 4 and 3 (each within the scatter of the next, the first and the last beyond it).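

With compound 4 this position gets its first direct comparison: in this assay, replacing trifluoromethyl with hydrogen gives a 1.5-fold lower number from compound 3 to compound 4 (0.18 log units; within the scatter), so this pair alone cannot separate the two groups. Hydrogen and methyl at the same place cannot be separated either, with a 1.6-fold higher number from compound 1 to compound 4 (0.21 log units; within the scatter), which leaves a 2.5-fold higher number from compound 1 to compound 3 (0.39 log units; beyond the scatter) as the only step at this position that clears the scatter, and the value for hydrogen falls inside that gap instead of forming a clear level of its own. At a different place in the molecule, chloro in place of methyl gives a 1.5-fold higher number from compound 2 to compound 4 (0.17 log units; within the scatter), so that change is also unresolved, and no measurement at hand explains where any of these numbers fall.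

The compounds shown leave open how an amine, a carboxylic acid or a methoxy group at this position would read, and whether any of them would move the number clearly away from the value for hydrogen. They also leave open whether a longer chain at this position would fit the narrow spread seen so far.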